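Swapping Chlorine for Methyl on the Benzyl Arm

A few compounds are considered here, and "the series" means these few. Any claim that something is new, unique, unknown or untested is made for them only; others in the source may bear on it.

Compound 1 `Cc1ccccc1Nc1nc(SCc2cn(Cc3ccccc3Cl)nn2)nc(-c2ccccc2)c1C#N` carries a 2-chlorophenyl group on the saturated chain carbon bound to an aromatic nitrogen, and in a functional assay on MCF7 cells (Homo sapiens) for inhibition, read by MTT assay, with a stated time of 72 h (a higher number here means a weaker inhibitor, a lower number a stronger inhibitor), compound 1 gives 7950 nM. Compound 2 `Cc1ccccc1Nc1nc(SCc2cn(Cc3ccc(Cl)cc3)nn2)nc(-c2ccccc2)c1C#N` instead has a 4-chlorophenyl group there. In this assay compound 2 reaches only a limit of the measurement, > 64000 nM, as recorded in the limit of > 64000 nM in this assay, at which 1 of the 2 values shown sits. The step of an at least 8.0-fold higher number from compound 1 to compound 2 (0.90 log units; beyond the scatter) therefore weakened inhibition. Compound 3 `Cc1ccc(Cn2cc(CSc3nc(Nc4ccccc4C)c(C#N)c(-c4ccccc4)n3)nn2)cc1` differs from compound 2 by methyl in place of chloro on an aromatic carbon. Within the data shown here, no measured step tests a chloro-to-methyl exchange, so the only guide is the weak standing of compound 2. Compound 3 is expected to remain near that limit, an estimated step of a number no higher from compound 2 to compound 3 (the limit leaves the size open). The estimate for compound 3 is 64000 nM, within 16000 nM to 250000 nM.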

Compound 3, half-maximal inhibitory concentration: > 64000 nM
Compound 3 ended at the assay's limit (the forecaster's own chance of this, stated with the estimate: 60%); the middle value sits exactly at the limit.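

The 4-methylphenyl group in place of 2-chlorophenyl gives an at least 8.0-fold higher number from compound 1 to compound 3 (0.90 log units; beyond the scatter). Weak inhibition here is therefore not tied to chlorine: both 4-chlorophenyl and 4-methylphenyl leave inhibition weaker than 2-chlorophenyl does. Compound 3, like compound 2, stands at a limit of this assay and not at a number, so the exchange of chloro for methyl cannot be read: the limit of > 64000 nM in this assay, at which 2 of the 3 values shown sit.

Going by these compounds, it remains open whether any group at this place on the ring can bring a reading inside the limit, such as a methoxy group or an amine. The compounds shown also do not tell whether a methyl group could replace the chlorine of 2-chlorophenyl.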